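From thiophen-2-yl to ethynyl on a shared core

The source may hold more compounds than are shown below. What is called first, only, known or untested is meant among the compounds shown, and "the series" means these compounds.

Compound 1 `COc1ncnc2c1c(-c1cc3ccccc3o1)cn2[C@@H]1O[C@H](CO)[C@@H](O)[C@H]1O`: 14500 nM
Compound 2 `CSc1ncnc2c1c(-c1cccs1)cn2[C@@H]1O[C@H](CO)[C@@H](O)[C@H]1O`: > 20000 nM

Both compounds were tested in a functional assay on HCT-116 cells (Homo sapiens), read by MTT assay, with a stated time of 72 h; a lower number here means a stronger inhibitor, a higher number a weaker inhibitor. In this assay compound 2 reports only a limit, > 20000 nM, and not a number. Compound 3 `C#Cc1cn([C@@H]2O[C@H](CO)[C@@H](O)[C@H]2O)c2ncnc(SC)c12` is the next case. It keeps the rest of compound 2 and changes one group: ethynyl in place of thiophen-2-yl on an aromatic carbon. Among the compounds with values here, no measured pair here shows what such a swap does, so any forecast is loose. Compound 1 does give a number, 14500 nM, so a measurable value on this core is expected to be within reach. A shift towards stronger inhibition is the expectation, of uncertain size, and the estimated change is an at least 6.6-fold lower number from compound 2 to compound 3 (0.82 log units; beyond the scatter). Compound 3 is estimated at 3000 nM, with an expected range from 400 nM to 20000 nM.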

Compound 3, half-maximal inhibitory concentration: 90 nM
Compound 3: the middle estimate sits 33-fold (1.52 log units) above what was measured; the measured number lies below the stated range.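

In this assay, the group on this aromatic carbon proves decisive: ethynyl in place of thiophen-2-yl gives an at least 220-fold lower number from compound 2 to compound 3 (2.34 log units; beyond the scatter). The true size of this step cannot be stated, because compound 2 gives only a limit of the assay and not a number: the limit of > 20000 nM in this assay, at which 1 of the 3 values shown sits.

The step also shows that a group with no ring and 2 heavy atoms can stand here in place of a five-membered aromatic ring with 5 heavy atoms, and that the number then falls far beyond the usual scatter.

This single step does not separate the part played by the triple bond from the part played by losing the ring. As far as these compounds go, how an ethyl group, a vinyl group or a nitrile would fare on this aromatic carbon remains open.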